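The compounds below may be only part of what the source reports. "The series", "measured", "known", "first", "only" and "open" are said of these compounds alone.

Compound 1 `C[C@@H]1C[C@@](O)(CC(=O)O)c2cc(F)ccc2O1` and compound 2 `C[C@@H]1C[C@@](O)(CC(=O)O)c2cc([N+](=O)[O-])ccc2O1` share one core, while compound 3 `CC1(C)C[C@@](O)(CC(=O)O)c2cc(F)ccc2O1` and the still unmeasured compound 4 `CC1(C)C[C@@](O)(CC(=O)O)c2cc([N+](=O)[O-])ccc2O1` share another; the difference between the two cores is not broken down here. In a functional assay on the whole organism (Sciatic nerve) for inhibition, with Rattus norvegicus as the target, with a stated time of 27 h (a lower number here means that less compound is needed, a higher number that more compound is needed for the effect), compound 1 gives 23 mg/kg and compound 2 gives 12 mg/kg. The change between them is nitro in place of fluoro on an aromatic carbon and it made a step of a 1.9-fold lower number from compound 1 to compound 2 (0.28 log units; within the scatter). Compound 3 gives 83.2 mg/kg, the highest of the three measured numbers, with its gaps to compound 1 and to compound 2 both beyond the scatter. The change from compound 3 to compound 4 is nitro in place of fluoro on an aromatic carbon, the same change carried onto the other core, at a place described in the same words. This change is seen only twice among the compounds shown, so the expectation rests on a single measured pair. Compound 4 is expected to move by a 1.8-fold lower number from compound 3 to compound 4 (0.27 log units; within the scatter), a step of the earlier size, because the step of a 1.9-fold lower number from compound 1 to compound 2 (0.28 log units; within the scatter) lay within the scatter and the number may equally not move at all. Compound 4 is estimated at 45 mg/kg, between 20 mg/kg and 100 mg/kg.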

Compound 4, dose for half-maximal effect: 37.2 mg/kg
Compound 4: the middle estimate sits 1.2-fold (0.08 log units) above what was measured; low and high end bracket the measured number.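

Putting nitro in place of fluoro on the aromatic carbon of the second core gives a 2.2-fold lower number from compound 3 to compound 4 (0.35 log units; beyond the scatter) in this assay. Set beside the same change on the first core, the step is of much the same size: the same change on two cores in this assay, a 1.9-fold lower number (0.28 log units; within the scatter) from compound 1 to compound 2 and a 2.2-fold lower number (0.35 log units; beyond the scatter) from compound 3 to compound 4, 1.2-fold (0.07 log units) apart, within the scatter of two such steps. For the compounds shown here, this shows that, across these two cores, the change carried over without a detectable difference in size, but it rests on only two pairs, and the step on the first core alone does not clear the scatter, so it does not show that the change would behave alike on a third core or why the number moves.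

The compounds shown leave open what other groups at that aromatic carbon would do, such as a nitrile, an amine or a methoxy group, since only fluoro and nitro appear there. They also leave open how the step would look on a core carrying a longer chain in place of the methyl groups.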